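The source may report more compounds than this note shows. Statements on the series, on what has been measured and on what is new or still open speak of the compounds shown alone.

Compound 1 `CCCCCCCS(=O)(=O)/C=C/c1ccc(O)c(O)c1` — 7100 nM
Compound 2 `O=S(=O)(/C=C/c1ccc(O)c(O)c1)CC1CCCN1` — 13800 nM
Compound 3 `O=S(=O)(/C=C/c1ccc(O)c(O)c1)CCC1CCCC1` — 6800 nM

In a functional assay, read by fluorescence and spectrophotometry, with a stated time of 1 h (on this read-out higher numbers stand for an effect only at larger amounts of compound and lower numbers for an effect already at smaller amounts), compound 2 shows the highest of the three numbers. Its nearest neighbour is compound 1: the change was a 1.9-fold higher number from compound 1 to compound 2 (0.29 log units; within the scatter). Its furthest is compound 3: that change was a 2.0-fold lower number from compound 2 to compound 3 (0.31 log units; beyond the scatter). Compound 1 and compound 3 sit together, as the change from compound 1 to compound 3 was a 1.0-fold lower number from compound 1 to compound 3 (0.02 log units; within the scatter).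

Compound 4 `O=S(=O)(/C=C/c1ccc(O)c(O)c1)CCCCCCCO` has not yet been measured. It differs from compound 2 in one place: 6-hydroxyhexyl in place of pyrrolidin-2-yl on a saturated chain carbon bound to a sulfonyl sulfur. Among the measured compounds shown here, two measured steps bear on this change, both of which exchange the group on the saturated chain carbon bound to the sulfonyl sulfur: the step to compound 2 from compound 1 and the step from compound 2 to compound 3. For the measured compounds named here, both moved the number down when the pyrrolidin-2-yl group was absent, one within the scatter and one modestly beyond it, and the terminal hydroxyl of the entering 6-hydroxyhexyl group has no measured counterpart here. The step to compound 4 is therefore expected to be a 1.7-fold lower number from compound 2 to compound 4 (0.24 log units; within the scatter), in the direction of a lower number. Compound 4 is estimated at 8000 nM, within 3500 nM to 20000 nM.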

Compound 4, half-maximal effective concentration: 5900 nM
Estimate against measurement, compound 4: 1.4-fold (0.13 log units) above; low and high end bracket the measured number.
By their numbers in this assay, from the lowest: compounds 4, 3, 1 and 2 (each within the scatter of the next, the first and the last beyond it).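

In this assay, the hydroxy group on the chain gets its first reading: the change is a 1.2-fold lower number from compound 1 to compound 4 (0.08 log units; within the scatter) and so does not separate it from hydrogen at this place, while a 1.2-fold lower number from compound 3 to compound 4 (0.06 log units; within the scatter) likewise leaves 5-hydroxypentyl and cyclopentyl unseparated. With 6-hydroxyhexyl in place of pyrrolidin-2-yl the change is a 2.3-fold lower number from compound 2 to compound 4 (0.37 log units; beyond the scatter), a second step out of compound 2 that lies beyond the scatter, although the step from compound 1 to compound 2 stays within it. Nothing available explains why these numbers fall as they do.

From the compounds shown here alone, whether an amine or a carboxylic acid in place of the hydroxy would stay level with compound 4 remains open. So does whether a longer chain would keep the number in the same range.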